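Swapping a Chloro-Fluoro Benzyl for a Chlorobenzyl Group

This account rests on a few compounds, and the source may have more. Where it says the series, first, only, none or still open, it means among the compounds named here.

Compound 1 `Cc1ccc2c(NCc3ccc(NC(=O)C4CCN(Cc5ncc[nH]5)CC4)cc3)nc(N(C)C)nc2c1`: > 20000 nM
Compound 2 `Cc1ccc2c(NCc3ccc(NC(=O)C4CCN(Cc5cccc(F)c5)CC4)cc3)nc(N(C)C)nc2c1`: > 4170 nM
Compound 3 `Cc1ccc2c(NCc3ccc(NC(=O)C4CCN(Cc5ccc(F)cc5Cl)CC4)cc3)nc(N(C)C)nc2c1`: > 5910 nM

In a functional assay on SV5A8 cells (Homo sapiens) for cytotoxicity (a higher number here means a weaker inhibitor, a lower number a stronger inhibitor), compound 1 gives > 20000 nM, which is a limit of the assay and not a number. Compound 2 gives > 4170 nM, likewise a limit. Compound 3 gives > 5910 nM, again a limit, so compound 3 stands with only a limit, as do the two other values. The steps a step that the two limits leave unreadable from compound 1 to compound 2, a step that the two limits leave unreadable from compound 1 to compound 3 and a step that the two limits leave unreadable from compound 2 to compound 3 therefore carry no readable size, because of the limit of > 20000 nM in this assay, at which 1 of the 3 values shown sits, the limit of > 4170 nM in this assay, at which 1 of the 3 values shown sits, and the limit of > 5910 nM in this assay, at which 1 of the 3 values shown sits, are all limits.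

Compound 4 `Cc1ccc2c(NCc3ccc(NC(=O)C4CCN(Cc5ccc(Cl)cc5)CC4)cc3)nc(N(C)C)nc2c1` differs from compound 3 by 4-chlorophenyl in place of 2-chloro-4-fluorophenyl on a saturated chain carbon bound to an amine nitrogen in a ring. The step from compound 2 to compound 3, which bears most closely on this change, gives no readable size, so no shift beyond the scatter can be foreseen. Compound 4 is expected to stay weak, with an estimated step that the limit leaves unreadable from compound 3 to compound 4. The estimate for compound 4 is 10000 nM, within 3000 nM to 40000 nM.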

Compound 4, half-maximal inhibitory concentration: > 3180 nM
Compound 4: no number, only a limit (the forecaster's own chance of this, stated with the estimate: 80%); the middle value lies beyond the limit too.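

Among these compounds, compound 4 gives > 3180 nM, which is again a limit of the assay and not a number, so no step from compound 1, compound 2 or compound 3 to compound 4 can be read. The compounds shown leave open what the actual value of any of them is in this assay, and whether swapping these groups changes it at all.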